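Swapping the Benzamide Phenyl for a Sulfonamide-Bearing Urea

This account rests on a few compounds, and the source may have more. Where it says the series, first, only, none or still open, it means among the compounds named here.

Compound 1 `O=C(Nc1cccc(-c2nc(-c3ccc(NC(=O)c4cccnc4)cc3Cl)no2)c1)c1ccccc1`: 12800 nM
Compound 2 `CCNC(=O)Nc1ccc(S(=O)(=O)Nc2cccc(-c3nc(-c4ccc(NC(=O)c5cccnc5)cc4Cl)no3)c2)cc1`: 3100 nM
Compound 3 `O=C(Nc1ccc(S(=O)(=O)Nc2cccc(-c3nc(-c4ccc(NC(=O)c5cccnc5)cc4Cl)no3)c2)cc1)NC1CCCC1`: > 10000 nM, a limit of the assay rather than a number

In a functional assay on MDA-MB-231 cells (Homo sapiens) for antiproliferative activity, read by MTT assay, with a stated time of 72 h (a higher number here means a weaker inhibitor, a lower number a stronger inhibitor), compound 1 gives 12800 nM, the higher of the two numbers measured; compound 2, with its sulfonamide and ethylurea, gives the lower one. Compound 3 sits at a limit (the limit of > 10000 nM in this assay, at which 1 of the 3 values shown sits). Compound 4 `CS(=O)(=O)Nc1ccc(NC(=O)Nc2cccc(-c3nc(-c4ccc(NC(=O)c5cccnc5)cc4Cl)no3)c2)cc1` differs from compound 1 by (4-(methanesulfonamido)phenyl)amino in place of phenyl on a carbonyl carbon. Going by the values given here, the only measured step, an at least 3.2-fold higher number from compound 2 to compound 3 (0.50 log units; beyond the scatter), concerns a different place and a bulkier group, so it bears only loosely here. Compound 2 shows that a polar urea-bearing arm can give a lower number than compound 1, so a modestly lower number is expected for compound 4, 5000 nM (range 1500 nM to 15000 nM), a step of a 2.6-fold lower number from compound 1 to compound 4 (0.41 log units; beyond the scatter).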

Compound 4, half-maximal inhibitory concentration: 600 nM
Estimate against measurement, compound 4: 8.3-fold (0.92 log units) above; the whole stated range lies above it.
By their numbers in this assay, from the lowest: compound 4; then compound 2; then compound 1.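

Replacing phenyl on the carbonyl carbon with (4-(methanesulfonamido)phenyl)amino gives, in this assay, a 21-fold lower number from compound 1 to compound 4 (1.33 log units; beyond the scatter). This position therefore accepts a much larger group, and the change brings a large gain rather than a loss. Nothing measured here explains that gain.

Going by these compounds, it remains open whether the step comes from the amino nitrogen or from the methanesulfonamido group. On these data alone, it is also open whether a simple amine or a carboxylic acid in place of the methanesulfonamido group would keep the gain.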